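The source may hold more compounds than are shown below. What is called first, only, known or untested is meant among the compounds shown, and "the series" means these compounds.

Compound 1 `COC(=O)c1ccc(NCc2cncn2Cc2ccccc2)cc1-c1ccccc1`: > 1000 nM, a limit of the assay
Compound 2 `COC(=O)c1ccc(NCc2cncn2Cc2ccccc2C)cc1-c1ccccc1`: 10000 nM
Compound 3 `COC(=O)c1ccc(NCc2cncn2Cc2ccccc2Cl)cc1-c1ccccc1`: 10000 nM

All three values come from a toxicity assay on NIH3T3 cells (Mus musculus) for cytotoxicity, read by resazurin assay; a higher number here means that more compound is needed for the effect, a lower number that less compound is needed. For compound 1 the reading is a limit and not a number. Compound 2 gives 10000 nM, and compound 3 stands level with it at 10000 nM.

Compound 4 `COC(=O)c1ccc(NCc2cncn2Cc2ccc([N+](=O)[O-])cc2)cc1-c1ccccc1` has not yet been measured. It departs from compound 3 as follows: 4-nitrophenyl in place of 2-chlorophenyl on a saturated chain carbon bound to an aromatic nitrogen. In words, 4-nitrophenyl stands in place of 2-chlorophenyl on a saturated chain carbon bound to an aromatic nitrogen.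

Among the compounds with values here, no measured step makes this exact change, so the evidence is indirect. The steps out of compound 1 give no size, being a step that the limit leaves unreadable from compound 1 to compound 2 and a step that the limit leaves unreadable from compound 1 to compound 3. Within the data shown here, the only readable step is no change at the digits printed from compound 2 to compound 3 (within the scatter), and it ends at compound 3. On that basis, no change beyond the scatter is expected in this assay, and no direction is favoured. The expected move is no change at the digits printed from compound 3 to compound 4 (within the scatter). For compound 4 the estimated value is 10000 nM, with an expected range from 3000 nM to 30000 nM.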

Compound 4, half-maximal effective concentration: > 10000 nM
Compound 4 ended at the assay's limit; the forecaster's own chance of this, stated with the estimate: 35%; the middle value lies on the limit itself.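

In this assay, 4-nitrophenyl in place of 2-chlorophenyl on the saturated chain carbon gives a number no lower from compound 3 to compound 4 (the limit leaves the size open), and 4-nitrophenyl in place of 2-methylphenyl gives a number no lower from compound 2 to compound 4 (the limit leaves the size open). Until now this place had held only phenyl, 2-methylphenyl and 2-chlorophenyl, and the new result shows that a nitro-bearing ring there does not bring the number down in this assay. Compound 4 reads > 10000 nM, which is a limit of the assay and not a number: the limit of > 10000 nM in this assay, at which 1 of the 4 values shown sits.

On these data alone, how far compound 4 lies past that limit stays open, and the step from compound 1 to compound 4 cannot be read. Also open, as far as these compounds go, is whether the reading goes with the nitro group or with its place on the ring, which 4-chlorophenyl and 2-nitrophenyl would separate, and how an amine on that ring would read.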